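A few compounds are considered here, and "the series" means these few. Any claim that something is new, unique, unknown or untested is made for them only; others in the source may bear on it.

In a functional assay on HepG2 cells (Homo sapiens) for cytotoxicity, read by MTT assay, with a stated time of 72 h (a lower number here means a stronger inhibitor, a higher number a weaker inhibitor), two compounds sharing one core have been measured so far. Compound 1 `O=C(N/N=C/c1ccc([N+](=O)[O-])cc1)Nc1cc2c(Nc3ccc(F)c(Cl)c3)ncnc2cc1O[C@H]1CCOC1` gives 35300 nM, and compound 2 `O=C(N/N=C/c1cccc(Cl)c1Cl)Nc1cc2c(Nc3ccc(F)c(Cl)c3)ncnc2cc1O[C@H]1CCOC1` gives 16900 nM, the lower of the two numbers and so the stronger result. Compound 3 `COc1ccc(/C=N/NC(=O)Nc2cc3c(Nc4ccc(F)c(Cl)c4)ncnc3cc2O[C@H]2CCOC2)c(OC)c1OC`, still to be measured, keeps the core of compound 2 and differs in one group: 2,3,4-trimethoxyphenyl in place of 2,3-dichlorophenyl on a carbon with a double bond to nitrogen. Put simply, 2,3,4-trimethoxyphenyl stands in place of 2,3-dichlorophenyl on a carbon with a double bond to nitrogen. Among the measured compounds shown here, only one measured step bears on this change, because it falls at the same place: a 2.1-fold lower number from compound 1 to compound 2 (0.32 log units; beyond the scatter). That step is modest, though beyond the usual scatter of this assay. For the measured compounds named here, one step is thin evidence, and no compound with a methoxy-bearing group has been measured yet. A change of similarly modest size is expected. Going by the values given here, compound 2, at 16900 nM, holds the lower of only two numbers, so a higher number is the more likely direction. The estimated step is a 1.4-fold higher number from compound 2 to compound 3 (0.13 log units; within the scatter). For compound 3 the estimated value is 23000 nM, with an expected range of 10000 nM to 50000 nM.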

Compound 3, half-maximal inhibitory concentration: 29300 nM
For compound 3 the middle estimate is 1.3-fold (0.11 log units) below the measured one; low and high end bracket the measured number.
By their numbers in this assay, from the lowest: compounds 2, 3 and 1 (each within the scatter of the next, the first and the last beyond it).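

In this assay, 2,3,4-trimethoxyphenyl is the only methoxy-bearing group shown on the carbon with a double bond to nitrogen, and putting it in place of 2,3-dichlorophenyl gives a 1.7-fold higher number from compound 2 to compound 3 (0.24 log units; within the scatter), so the two groups cannot be told apart here, even though chlorine gives way to oxygen and hydrogen-bond acceptors appear. The same holds against 4-nitrophenyl, with a 1.2-fold lower number from compound 1 to compound 3 (0.08 log units; within the scatter), which means compound 3 cannot be ranked against either of the other two, although compound 1 and compound 2 are separated by a step just beyond the scatter. Nothing shown here offers an explanation for these numbers.

From the compounds shown here alone, all three compounds carry a substituted phenyl ring at this place, so it remains open whether an amine or a carboxylic acid on that ring, or a longer carbon chain in place of the ring, would move the number by more than these small steps. It is also open how much each methoxy group contributes, since a phenyl ring with a single methoxy group does not appear among these compounds.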